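The compounds below may be only part of what the source reports. "The series", "measured", "known", "first", "only" and "open" are said of these compounds alone.

Compound 1 `Nc1ccccc1/C=C/c1ccccc1O` is the starting point. In a functional assay on MCF7 cells (Homo sapiens) for inhibition, read by MTT assay, with a stated time of 2 days (a higher number here means a weaker inhibitor, a lower number a stronger inhibitor), compound 1 gives 39 ug/mL. Compound 2 `COc1ccccc1/C=C/c1ccccc1O` differs from it by methoxy in place of amino on an aromatic carbon; in this assay compound 2 gives 17.9 ug/mL, so that change made a 2.2-fold lower number from compound 1 to compound 2 (0.34 log units; beyond the scatter). Compound 3 `Nc1ccc(/C=C/c2cccc(O)c2)cc1` is built from the same atoms as compound 1, joined differently; the difference between the two cores is not broken down here. In this assay compound 3 gives 24.8 ug/mL. The not yet measured compound 4 `COc1ccc(/C=C/c2cccc(O)c2)cc1` differs from compound 3 by methoxy in place of amino on an aromatic carbon. Among the measured compounds shown here, this is the same kind of change as the one from compound 1 to compound 2, but not the same: in the first case the group sits ortho to a group of 9 heavy atoms, in the second case para to a group of 9 heavy atoms. For the measured compounds named here, the step from compound 3 to compound 4 is expected to be about a 1.9-fold lower number from compound 3 to compound 4 (0.28 log units; within the scatter), resting on the single earlier example, in which the same kind of change gave a 2.2-fold lower number from compound 1 to compound 2 (0.34 log units; beyond the scatter). Compound 4 is accordingly estimated at 13 ug/mL, with a likely range from 7 ug/mL to 25 ug/mL.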

Compound 4, half-maximal inhibitory concentration: 21 ug/mL
Estimate against measurement, compound 4: 1.6-fold (0.21 log units) below; the range from low to high includes it.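

In this assay, replacing amino with methoxy on the core of compound 3 gave a 1.2-fold lower number from compound 3 to compound 4 (0.07 log units; within the scatter), a step that cannot be told apart from the ordinary variation between repeated measurements. Set beside the earlier example, this step does not differ from it by more than such measurements can resolve: the same change on two cores in this assay, a 2.2-fold lower number (0.34 log units; beyond the scatter) from compound 1 to compound 2 and a 1.2-fold lower number (0.07 log units; within the scatter) from compound 3 to compound 4, 1.8-fold (0.27 log units) apart, within the scatter of two such steps. The result is therefore compatible with the change carrying over from one core to the other with a similar effect, but it does not prove this, since one step stands clear of the scatter, the other does not, and two pairs are a thin basis for any rule.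

On these data alone, it remains open how other groups on the same aromatic carbon would compare with amino and methoxy, for example a chlorine atom, a nitrile or a longer ether such as ethoxy. Also open, as far as these compounds go, is whether the same swap would behave in a similar way in other types of cell.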